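This account rests on a few compounds, and the source may have more. Where it says the series, first, only, none or still open, it means among the compounds named here.

Compound 1 `O=C(NC/C=C\Cn1ccc(=O)[nH]c1=O)c1ccccc1` and compound 2 `Nc1ccn(C/C=C\CNC(=O)c2ccccc2)c(=O)n1` carry the same benzamide on the same unsaturated four-carbon chain but end in different rings; the difference between the two cores is not broken down here. Compound 3 `O=C(NC/C=C\Cn1ccc(=O)[nH]c1=O)c1ccc(F)cc1` arises from compound 1 by fluoro in place of hydrogen on an aromatic carbon. The same kind of change, made on compound 2, gives compound 4 `Nc1ccn(C/C=C\CNC(=O)c2ccc(F)cc2)c(=O)n1`, namely (fluoro in place of hydrogen on an aromatic carbon); the two "place" descriptions agree word for word, so the surroundings of the new fluorine are the same in both pairs.

In a functional assay on MCF7 cells (Homo sapiens) for cytotoxicity, read by MTT assay, with a stated time of 72 h (a lower number here means a stronger inhibitor, a higher number a weaker inhibitor), compound 1 gives only a limit, > 100000 nM. In this assay compound 2 gives 31400 nM, while compound 3 gives 2700 nM, so compound 2 holds the highest of the two numbers that were read. Going by the values given here, the one measured instance of the fluorine change is an at least 37-fold lower number from compound 1 to compound 3 (1.56 log units; beyond the scatter), and its true size is known only as a lower bound because of the limit of > 100000 nM in this assay, at which 1 of the 3 values shown sits.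

Carrying that change over, the step from compound 2 to compound 4 is expected to be a 26-fold lower number from compound 2 to compound 4 (1.42 log units; beyond the scatter). That expectation rests on the measured step of an at least 37-fold lower number from compound 1 to compound 3 (1.56 log units; beyond the scatter). It also rests on the starting point of compound 2, 31400 nM. On that basis compound 4 is expected to give about 1200 nM in this assay, most likely between 250 nM and 8000 nM.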

Compound 4, half-maximal inhibitory concentration: > 100000 nM
Compound 4 was reported as a limit; the forecaster's own chance of this, stated with the estimate: 5%; middle value at least 83-fold (1.92 log units) from the limit.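

In this assay, the same fluorine change that strengthened the compound on the core of compound 1 goes the other way on the core of compound 2, giving an at least 3.1-fold higher number from compound 2 to compound 4 (0.50 log units; beyond the scatter), so in this series the change cannot be carried from one core to the other and be expected to act alike: the same change on two cores in this assay, an at least 37-fold lower number (1.56 log units; beyond the scatter) from compound 1 to compound 3 and an at least 3.1-fold higher number (0.50 log units; beyond the scatter) from compound 2 to compound 4, at least 110-fold (2.07 log units) apart, beyond the scatter of two such steps. From the compounds shown here alone, compound 1 and compound 4 both gave only a limit rather than a number, so each step is known only as a lower bound and its true size stays unknown: the limit of > 100000 nM in this assay, at which 2 of the 4 values shown sit. These two pairs show that the outcome of the change differed with the core, but they do not show why it differed, and they give no rule for any other core.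

Going by these compounds, it remains open whether chloro or methoxy in place of the fluoro would show the same split on these two cores. On these data alone, it also remains open whether the split would survive a longer chain in place of the unsaturated four-carbon chain that links the benzamide to each core.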